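Compound 2 and the step to compound 4

The source may hold more compounds than are shown below. What is called first, only, known or untested is meant among the compounds shown, and "the series" means these compounds.

In a physicochemical assay for lipophilicity (on this read-out higher numbers stand for higher lipophilicity and lower numbers for lower lipophilicity), compound 2 `CCNC(=O)Nc1ccc(-c2nc(C(C)(C)S(C)(=O)=O)cc([C@@]34CCOC[C@@H]3C4)n2)cc1` gives 4.7. Among the measured compounds shown here, its mirror image, compound 3 `CCNC(=O)Nc1ccc(-c2nc(C(C)(C)S(C)(=O)=O)cc([C@]34CCOC[C@H]3C4)n2)cc1`, gives 4.7, and the two stand level as the highest of the three numbers so far. Compound 1 `CC(C)(c1cc([C@@]23CCOC[C@@H]2C3)nc(-c2ccc(NC(=S)NCCO)cc2)n1)S(C)(=O)=O` gives 3.9, the furthest from compound 2.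

Compound 4 `CCNC(=O)Nc1ccc(-c2nc(CS(C)(=O)=O)cc([C@@]34CCOC[C@@H]3C4)n2)cc1` departs from compound 2 in a single group: (methylsulfonyl)methyl in place of 1-methyl-1-(methylsulfonyl)ethyl on an aromatic carbon. The change lies on an aromatic carbon, and the entering group is the smaller of the two.

Neither measured step touches this group, so both bear on it only indirectly. The first, a number 0.80 log units higher from compound 1 to compound 2 (beyond the scatter), concerns a different group, on a nitrogen on an aromatic ring, and serves only as a yardstick for what one change of a small group has done on this scale. The second, no change at the digits printed from compound 2 to compound 3 (within the scatter), goes with the fact that compounds 2 and 3 differ only in the configuration as drawn, so it says nothing about a change of atoms.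

For the measured compounds named here, with the yardstick of compound 2 at a number 0.80 log units higher from compound 1 to compound 2 (beyond the scatter), a modest step towards a lower number is expected, though no measured step tests that direction. The expected move is a number 0.60 log units lower from compound 2 to compound 4 (beyond the scatter). For compound 4 the estimated value in this assay is 4.1, with an expected range of 3.7 to 4.5.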

Compound 4, partition coefficient: 3.6
Estimate against measurement, compound 4: 0.50 log units above; measured number below the stated range.
By their numbers in this assay, from the lowest: compounds 4 and 1 (each within the scatter of the next); then compounds 2 and 3 (each within the scatter of the next).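

In this assay, among the compounds shown here, replacing 1-methyl-1-(methylsulfonyl)ethyl with (methylsulfonyl)methyl on this aromatic carbon gives a number 1.10 log units lower from compound 2 to compound 4 (beyond the scatter), the first reading of a change at this position and a large step on this scale. The two groups have the same counts of hydrogen-bond donors, hydrogen-bond acceptors and double bonds outside aromatic rings, and neither has a ring or a net charge, so among the features counted here they differ only in their atoms, with fewer heavy carbon atoms in the entering group. Nothing measured here accounts for the size of this step.

The compounds shown leave open how this assay responds on this aromatic carbon to a group without the sulfonyl, such as a plain methyl, an amine or a carboxylic acid, or to a longer chain carrying the sulfonyl. They also leave open whether the same exchange would give a similar step with the other group on the nitrogen, as in compound 1, or in the mirror-image series of compound 3.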